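A few compounds are considered here, and "the series" means these few. Any claim that something is new, unique, unknown or untested is made for them only; others in the source may bear on it.

Of the compounds shown here, three sharing one core have been measured in a functional assay on PC-3 cells (Homo sapiens) for cytotoxicity, read by MTT assay, with a stated time of 72 h; on this read-out lower numbers stand for stronger inhibition and higher numbers for weaker inhibition. There, compound 1 `CC1=C(/C=C/C(=O)/C=C/c2cccc(F)c2)C(C)(C)CCC1` gives 18700 nM, compound 2 `CC1=C(/C=C/C(=O)/C=C/c2ccc(F)cc2)C(C)(C)CCC1` gives 25800 nM and compound 3 `CC1=C(/C=C/C(=O)/C=C/c2cccc(C)c2)C(C)(C)CCC1` gives 35000 nM. Compound 1 therefore stands level with the other two, since its values and theirs lie within the scatter of one another.

Compound 4 `CC1=C(/C=C/C(=O)/C=C/c2cccc(F)c2)C(C)(C)CCC1O` keeps the core of compound 1 but carries hydroxy in place of hydrogen on a saturated ring carbon. The measured steps are a 1.4-fold higher number from compound 1 to compound 2 (0.14 log units; within the scatter), a 1.9-fold higher number from compound 1 to compound 3 (0.27 log units; within the scatter) and a 1.4-fold higher number from compound 2 to compound 3 (0.13 log units; within the scatter). All three lie within the scatter, but all three are changes on the aromatic ring. None of them touches the saturated ring, so they bear on the new change only indirectly. Going by the values given here, they show that this assay has so far moved little across this small set, and the data hold no measured step at the saturated ring carbon.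

The expectation therefore starts from compound 1 at 18700 nM, with no step in either direction beyond the scatter, and with a wide margin for the untested position. The expected change is a 1.1-fold higher number from compound 1 to compound 4 (0.03 log units; within the scatter). For compound 4 the estimated value is 20000 nM, with an expected range from 8000 nM to 50000 nM.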

Compound 4, half-maximal inhibitory concentration: 16000 nM
Compound 4: the middle estimate sits 1.3-fold (0.10 log units) above what was measured; low and high end bracket the measured number.
By their numbers in this assay, from the lowest: compounds 4, 1, 2 and 3 (each within the scatter of the next, the first and the last beyond it).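

In this assay, going by these compounds alone, compound 4 supplies the first measured step at the saturated ring carbon, a 1.2-fold lower number from compound 1 to compound 4 (0.07 log units; within the scatter), and this step lies within the scatter. The earlier steps shown here all concerned the aromatic ring, so they could not show what this one does: a saturated ring carbon next to the ring atom that bears a methyl group can carry hydroxy in place of hydrogen while the number stays within the scatter of compound 1. The information at hand offers no explanation for this result.

A single step at a single carbon leaves open whether other groups at this position, such as an amine, a methoxy group or a carboxylic acid, would also keep the number within the scatter of compound 1. It also leaves open whether hydroxy at this carbon would give a similar result alongside the 4-fluorophenyl of compound 2 or the 3-methylphenyl of compound 3, and whether the other saturated ring carbons would accept the same change.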